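Methoxy on the anilino ring of compound 1

The compounds below may be only part of what the source reports. "The series", "measured", "known", "first", "only" and "open" are said of these compounds alone.

Compound 1 `Cc1nc(SCC(=O)Nc2nc(-c3ccc(Cl)cc3)cs2)n(Nc2ccccc2)c1C` and compound 2 `Cc1ccc(Nn2c(SCC(=O)Nc3nc(-c4ccccc4)cs3)nc(C)c2C)cc1` were examined in a functional assay on MOLT-4 cells (Homo sapiens) for antiproliferative activity, read by sulforhodamine B assay, with a stated time of 48 h; a lower number here means a stronger inhibitor of growth, a higher number a weaker inhibitor of growth. In this assay compound 1 gives 2510 nM, and compound 2 gives 3460 nM. Compound 1 stands at the lower end of these two numbers, but the two lie within the usual scatter of each other, so no order between them can be claimed. Compound 3 `COc1ccc(Nn2c(SCC(=O)Nc3nc(-c4ccc(Cl)cc4)cs3)nc(C)c2C)cc1` has not yet been measured in this assay. It differs from compound 1 in a single place: methoxy in place of hydrogen on an aromatic carbon. Among the measured compounds shown here, no step between measured compounds isolates this change. Compound 2, which differs from compound 1 in more than one place, still gives a number within the scatter of compound 1, so no shift beyond the scatter is expected in this assay. The expected step of a 1.1-fold higher number from compound 1 to compound 3 (0.05 log units; within the scatter) is accordingly small. Compound 3 is estimated at 2800 nM, within a range from 1200 nM to 6500 nM.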

Compound 3, concentration for 50% growth inhibition: 2540 nM
Estimate against measurement, compound 3: 1.1-fold (0.04 log units) above, and the stated range covers the measured number.
By their numbers in this assay, from the lowest: compounds 1, 3 and 2 (each within the scatter of the next).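

In this assay, among the compounds shown here, methoxy in place of hydrogen on the anilino ring, para to a large group, gives a 1.0-fold higher number from compound 1 to compound 3 (0.01 log units; within the scatter) and is the first step that isolates this change. At this position, then, going from phenyl to 4-methoxyphenyl brings no shift that can be read, something the earlier pair could not show, as those two compounds differ in more than one place. No measurement at hand explains this result. 

As far as these compounds go, whether the same holds for other groups at this position, such as an amine, a carboxylic acid or a longer chain like butoxy, stays open. Also open, from the compounds shown here alone, is whether methoxy would read the same elsewhere on this ring, or on the anilino ring of a compound with a different core.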